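Fluoro for Hydroxy on the Hydrazone Aryl Ring

A few compounds are considered here, and "the series" means these few. Any claim that something is new, unique, unknown or untested is made for them only; others in the source may bear on it.

In a functional assay on A549 cells (Homo sapiens) for cytotoxicity, read by MTT assay, with a stated time of 72 h (on this read-out higher numbers stand for weaker inhibition and lower numbers for stronger inhibition), compound 1 `CN(C)CCn1cnnc1-c1cc(Oc2ccc(NC(=O)N/N=C/c3ccc(F)cc3)cc2F)ccn1` gives 1790 nM. In this assay compound 2 `CN(C)CCn1cnnc1-c1cc(Oc2ccc(NC(=O)N/N=C/c3ccc(O)c(O)c3)cc2F)ccn1` reaches only a limit of the assay, > 100000 nM. Compound 2 thus sits at the limit of > 100000 nM in this assay, at which 1 of the 2 values shown sits, the top of the numbers shown. Within the data shown here, the only measured step is an at least 55-fold higher number from compound 1 to compound 2 (1.74 log units; beyond the scatter). Compound 3 `CN(C)CCn1cnnc1-c1cc(Oc2ccc(NC(=O)N/N=C/c3ccc(O)c(F)c3)cc2F)ccn1` differs from compound 2 by fluoro in place of hydroxy on an aromatic carbon, a change that moves partway back toward compound 1. The step of an at least 5.0-fold lower number from compound 2 to compound 3 (0.69 log units; beyond the scatter) is therefore expected to run toward compound 1, smaller than the measured step. Compound 3 is estimated at 20000 nM, within 4000 nM to 100000 nM.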

Compound 3, half-maximal inhibitory concentration: 13400 nM
The estimate for compound 3 lay 1.5-fold (0.17 log units) above the measured number; the range from low to high includes it.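

In this assay, the 3,4-dihydroxyphenyl group need not lose all measurable response, since fluoro in place of hydroxy on this ring gives an at least 7.4-fold lower number from compound 2 to compound 3 (0.87 log units; beyond the scatter). Compound 2 is recorded only as a limit, so this step gives a bound and not an exact size: the limit of > 100000 nM in this assay, at which 1 of the 3 values shown sits. The recovery is partial, as the 3-fluoro-4-hydroxyphenyl group still gives a 7.5-fold higher number from compound 1 to compound 3 (0.87 log units; beyond the scatter). The compounds shown leave open whether the remaining hydroxy accounts for this gap, and whether a methoxy group or an amine on the same carbon would behave as fluoro does.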